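Replacing methylamino with trifluoromethyl: a lipophilicity estimate

The source may hold more compounds than are shown below. What is called first, only, known or untested is meant among the compounds shown, and "the series" means these compounds.

Compounds measured so far in a physicochemical assay for lipophilicity, read by HPLC, at pH 7.5 (on this read-out higher numbers stand for higher lipophilicity and lower numbers for lower lipophilicity), are these:

- compound 1 `CC[C@@H](Nc1c(C#N)c(-c2ccc(-c3cccc(Cl)c3F)cc2)nc2cnccc12)C(N)=O` gives 3.1
- compound 2 `CC[C@@H](Nc1c(C#N)c(-c2ccc(-c3cccc(Cl)c3)cc2)nc2cnccc12)C(N)=O` gives 3.1
- compound 3 `CC[C@@H](Nc1c(C#N)c(-c2ccc(-c3ccccc3NC)cc2)nc2cnccc12)C(N)=O` gives 2.5

In this assay compound 3 stands lowest of the three at 2.5 and the other two lie above it, beyond the scatter. Compound 4 `CC[C@@H](Nc1c(C#N)c(-c2ccc(-c3ccccc3C(F)(F)F)cc2)nc2cnccc12)C(N)=O` is still unmeasured. It differs from compound 3 in one place, with trifluoromethyl in place of methylamino on an aromatic carbon, ortho to a large group (trifluoromethyl in place of methylamino on an aromatic carbon).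

For the measured compounds named here, no measured compound carries trifluoromethyl, so the evidence is indirect. Going by the values given here, two steps bear on the change, each modest and beyond the scatter: a number 0.60 log units lower from compound 1 to compound 3 (beyond the scatter) and a number 0.60 log units lower from compound 2 to compound 3 (beyond the scatter) when 2-(methylamino)phenyl replaces the chlorine-bearing phenyl groups. The step with hydrogen in place of fluoro shows no change at the digits printed from compound 1 to compound 2 (within the scatter) and suggests that such a small edit at this group need not shift the number. Compound 1 (3.1) and compound 2 (3.1) both lack methylamino, so a modest rise is expected. The expected change is a number 0.60 log units higher from compound 3 to compound 4 (beyond the scatter) in this assay and matches those two steps in size, in reverse. For compound 4 the estimated value is 3.1 (expected range 2.7 to 3.5).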

Compound 4, distribution coefficient: 3.1
The estimate for compound 4 equals the measured number at the digits printed; low and high end bracket the measured number.
By their numbers in this assay, from the lowest: compound 3; then compounds 1, 2 and 4 (each within the scatter of the next).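

In this assay, the swap at this position, on an aromatic carbon ortho to a large group, now has a direct reading: a number 0.60 log units higher from compound 3 to compound 4 (beyond the scatter). Earlier, the methylamino compound could be set only against chlorine-bearing phenyl groups, whereas this step isolates methylamino and trifluoromethyl as the only difference. The other two steps place the new group level with those chlorine-bearing groups, with no change at the digits printed from compound 2 to compound 4 (within the scatter) and no change at the digits printed from compound 1 to compound 4 (within the scatter), so among these four compounds compound 3 alone stands apart, and nothing shown gives a measured reason for that.

The compounds shown leave open whether the step comes from losing methylamino or from gaining trifluoromethyl, since a single swap cannot separate the two; a plain hydrogen, a methyl or a methoxy group at the same place would divide the step between them. As far as these compounds go, it also remains open whether an amine with a second methyl group, such as dimethylamino, would stand with compound 3 or with compound 4, and whether trifluoromethyl would read the same as 3-(trifluoromethyl)phenyl.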